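The source may hold more compounds than are shown below. What is called first, only, known or untested is meant among the compounds shown, and "the series" means these compounds.

Of the compounds shown here, three built on one shared core have been tested in an ADME assay (Homo sapiens) for cytotoxicity; on this read-out lower numbers stand for higher toxicity in this test and higher numbers for lower toxicity in this test. Compound 1 `NNCc1cc(O)n2nc(N)c([N+](=O)[O-])c2n1` carries only hydrogen on an amine nitrogen, and in this assay compound 1 gives 42.6 ug/mL. Compound 2 `COc1ccc(NNCc2cc(O)n3nc(N)c([N+](=O)[O-])c3n2)cc1` carries a 4-methoxyphenyl group on that amine nitrogen, and in this assay compound 2 gives 66.3 ug/mL; the step of a 1.6-fold higher number from compound 1 to compound 2 (0.19 log units; within the scatter) lies within the scatter. Compound 3 `Nc1nn2c(O)cc(CNNCCO)nc2c1[N+](=O)[O-]` carries a 2-hydroxyethyl group on the same amine nitrogen. For compound 3 in this assay only a limit is reported, > 50 ug/mL, so compound 3 stands at the limit of > 50 ug/mL in this assay, at which 1 of the 3 values shown sits. The step of an at least 1.1-fold higher number from compound 1 to compound 3 (0.06 log units; that floor lies within the scatter) and the step that the limit leaves unreadable from compound 2 to compound 3 therefore say little about where compound 3 stands beside compound 1 and compound 2.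

Compound 4 `Nc1nn2c(O)cc(CNNC(N)S)nc2c1[N+](=O)[O-]` differs from compound 3 in one place: amino(sulfanyl)methyl in place of 2-hydroxyethyl on an amine nitrogen. No measured change on this amine nitrogen has moved the number beyond the scatter, because the step of a 1.6-fold higher number from compound 1 to compound 2 (0.19 log units; within the scatter) stayed within it and the step of an at least 1.1-fold higher number from compound 1 to compound 3 (0.06 log units; that floor lies within the scatter) gave only a floor within it. The step that the limit leaves unreadable from compound 3 to compound 4 is therefore expected to stay within the scatter as well. Compound 4 is estimated to give 55 ug/mL, between 25 ug/mL and 120 ug/mL, with a fair chance that again only a limit is reported.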

Compound 4, half-maximal cytotoxic concentration: > 50 ug/mL
Compound 4: no number, only a limit; the forecaster's own chance of this, stated with the estimate: 50%; the middle value does not contradict the limit.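

Like compound 3, compound 4 is reported in this assay only as a limit, > 50 ug/mL. Placing amino(sulfanyl)methyl on this amine nitrogen, a group with sulfur and nitrogen instead of the oxygen of 2-hydroxyethyl, therefore gives a second limit, and the only readable comparison is an at least 1.1-fold higher number from compound 1 to compound 4 (0.06 log units; that floor lies within the scatter), so this change shows no step beyond the scatter in the direction of higher toxicity in this test. The steps to compound 4 from compound 2 and from compound 3 cannot be read, and limits now make up a large part of this small set: the limit of > 50 ug/mL in this assay, at which 2 of the 4 values shown sit.

From the compounds shown here alone, how far the true values of compound 3 and compound 4 lie from their limits stays open, so these two side chains cannot be ordered against each other or against 4-methoxyphenyl. Also open, going by these compounds, is whether a carboxylic acid or a longer chain on this amine nitrogen would produce a step beyond the scatter, which no readable step here has done.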